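Benzyl in place of ethyl on the ring nitrogen

The source may hold more compounds than are shown below. What is called first, only, known or untested is meant among the compounds shown, and "the series" means these compounds.

Compound 1 `CO[C@@]12CCN(Cc3ccccc3)C[C@H]1[C@H](c1ccc3ccccc3c1)C(C#N)=C(N)O2`: 23400 nM in a functional assay on trachea (Cavia porcellus); a higher number here means a weaker inhibitor, a lower number a stronger inhibitor
Compound 2 `CCN1CC[C@@]2(OC)OC(N)=C(C#N)[C@@H](c3ccc(Br)cc3)[C@@H]2C1`: 13200 nM in this assay
Compound 3 `CCN1CC[C@@]2(OC)OC(N)=C(C#N)[C@@H](c3ccc(Cl)cc3)[C@@H]2C1`: 14900 nM in this assay

Within the data shown here, compound 3 sits among three numbers that all lie within the scatter of one another; its step from compound 2, a 1.1-fold higher number from compound 2 to compound 3 (0.05 log units; within the scatter), is the only measured step, and it concerns a different change. Compound 4 `CO[C@@]12CCN(Cc3ccccc3)C[C@H]1[C@H](c1ccc(Cl)cc1)C(C#N)=C(N)O2` differs from compound 3 by phenyl in place of methyl on a saturated chain carbon bound to an amine nitrogen in a ring. Among the measured compounds shown here, no measured step isolates this change: compound 1 also carries a benzyl, but it differs from compound 3 in the other aromatic group as well, and its value and that of compound 3 are within the scatter. No step beyond the scatter is therefore expected in this assay, a 1.1-fold higher number from compound 3 to compound 4 (0.06 log units; within the scatter). Compound 4 is estimated at 17000 nM, between 7000 nM and 40000 nM.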

Compound 4, half-maximal inhibitory concentration: 18500 nM
The estimate for compound 4 lay 1.1-fold (0.04 log units) below the measured number; low and high end bracket the measured number.
By their numbers in this assay, from the lowest: compounds 2, 3, 4 and 1 (each within the scatter of the next).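

The change from ethyl to benzyl now has a measured step of its own: in this assay, it gives a 1.2-fold higher number from compound 3 to compound 4 (0.09 log units; within the scatter), so adding a phenyl at this place leaves the number within the scatter. With benzyl kept on both compounds, the aromatic group can also be compared directly, and 4-chlorophenyl in place of naphthalen-2-yl gives a 1.3-fold lower number from compound 1 to compound 4 (0.10 log units; within the scatter), which is also within the scatter. Nothing available explains why these numbers stay so close. On these data alone, whether a longer chain such as butyl, or an amine or a carboxylic acid at this place, would move the number beyond the scatter stays open.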